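Swapping a methoxy for an oxolanyloxy on a shared core

This account rests on a few compounds, and the source may have more. Where it says the series, first, only, none or still open, it means among the compounds named here.

Of the compounds shown here, two sharing one core have been tested in a functional assay on PC-3 cells (Homo sapiens) for antiproliferative activity, read by MTT assay, with a stated time of 72 h; a higher number here means a weaker inhibitor, a lower number a stronger inhibitor. Compound 2 (`COc1cc2ncnc(N3CCc4ccccc43)c2cc1NC(=O)/C=C/CN(C)C`) gives 2190 nM, and compound 1 (`C=CC(=O)Nc1cc2c(N3CCc4ccccc43)ncnc2cc1O[C@@H]1CCOC1`) gives 2710 nM; the two numbers cannot be told apart within the usual scatter, so neither stands clearly ahead. Compound 3 (`CN(C)C/C=C/C(=O)Nc1cc2c(N3CCc4ccccc43)ncnc2cc1O[C@@H]1CCOC1`) differs from compound 2 by oxolan-3-yl in place of methyl on an oxygen on an aromatic ring. With no direct comparison of this change available, the expected step of a 1.1-fold higher number from compound 2 to compound 3 (0.04 log units; within the scatter) is none beyond the scatter, because compound 1, which already carries this group, gives 2710 nM. Compound 3 is therefore estimated at 2400 nM, expected between 1000 nM and 6000 nM.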

Compound 3, half-maximal inhibitory concentration: 1230 nM
Beside the measured number, compound 3's estimate is 2.0-fold (0.29 log units) above it; the range from low to high includes it.
By their numbers in this assay, from the lowest: compounds 3, 2 and 1 (each within the scatter of the next, the first and the last beyond it).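

The swap of methoxy to (oxolan-3-yl)oxy gives a 1.8-fold lower number from compound 2 to compound 3 (0.25 log units; within the scatter) in this assay, so this change on an oxygen on an aromatic ring cannot be told apart from the usual scatter. On the carbonyl carbon, 3-(dimethylamino)prop-1-en-1-yl in place of vinyl gives a 2.2-fold lower number from compound 1 to compound 3 (0.34 log units; beyond the scatter), a modest step and the only one here that clears the scatter. Nothing available explains either step. Going by these compounds, it remains open how a longer alkoxy chain on that oxygen, or a cyclic amine such as morpholine at the end of the chain on the carbonyl carbon, would affect the number.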